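A Larger Group Replaces Methyl on Compound 2

The source may report more compounds than this note shows. Statements on the series, on what has been measured and on what is new or still open speak of the compounds shown alone.

Going by the values given here, compound 2 `Cc1cccc(-c2onc3ccc(C(=O)O)cc23)c1` stands at the lower of the two numbers known so far: in an assay for inhibition of inositol hexakisphosphate kinase 2 (Homo sapiens), read by colorimetric assay, coupled enzyme assay and malachite green, with a stated time of 120 min, in the presence of a further agent that is not named here (on this read-out lower numbers stand for stronger inhibition and higher numbers for weaker inhibition), compound 2 gives 150 nM. Compound 1 `O=C(O)c1ccc2noc(-c3ccc(Oc4ncc(Cl)cc4Cl)cc3)c2c1` gives 650 nM in this assay, a higher number that lies beyond the scatter. Compound 3 `O=C(O)c1ccc2noc(-c3cccc(-c4ccccc4)c3)c2c1` differs from compound 2 by phenyl in place of methyl on an aromatic carbon. Among the compounds with values here, no measured pair follows this change, so the step is expected to be small, without a clear direction, and is estimated as a 1.3-fold higher number from compound 2 to compound 3 (0.12 log units; within the scatter). Compound 3 is therefore expected to give about 200 nM in this assay, within a range from 60 nM to 700 nM.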

Compound 3, half-maximal inhibitory concentration: 130 nM
Compound 3: middle estimate off by 1.5-fold (0.19 log units), on the high side; the measured number falls inside the stated range.
By their numbers in this assay, from the lowest: compounds 3 and 2 (each within the scatter of the next); then compound 1.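

In this assay, the carbon meta to a large group carries phenyl in place of methyl with a step of a 1.2-fold lower number from compound 2 to compound 3 (0.06 log units; within the scatter), so the number stays within the scatter even though methyl's single carbon gives way to a whole six-membered aromatic ring. Compounds 2 and 3 therefore show that this position accepts a much larger all-carbon group in this assay. Nothing given here explains this result. As far as these compounds go, whether an amine, a carboxylic acid or a longer chain at this position would give a similar number remains open. So does the effect of a chlorine or a methoxy group on the added phenyl.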